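The compounds below may be only part of what the source reports. "The series", "measured", "known", "first", "only" and "open" are said of these compounds alone.

Compound 1, with the structure `CC(=O)c1cc(-c2ccc(F)cc2)cc2cc(-c3ccccc3)[nH]c12`, serves as the starting point. In a functional assay on HeLa cells (Homo sapiens) for cytotoxicity, read by MTT assay, with a stated time of 2 days, tested at 1 uM (a lower number here means a stronger effect, a higher number a weaker effect of the compound at the concentration tested), compound 1 gives 82.7%. Compound 2, `COc1ccc(-c2cc(C(C)=O)c3[nH]c(-c4ccccc4)cc3c2)cc1`, carries the change methoxy in place of fluoro on an aromatic carbon relative to compound 1, and in this assay compound 2 gives 73.1%; the step is a number 9.6 percentage points lower from compound 1 to compound 2 (within the scatter). Compound 3, `CC(=O)c1cc(-c2ccccc2)cc2cc(-c3ccc(F)cc3)[nH]c12`, is built from the same atoms as compound 1, joined differently, and the difference between the two cores is not broken down here. In this assay compound 3 gives 85.1%, a number that sits beside that of compound 1 within the scatter, while against compound 2 the two values lie apart by more than the scatter.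

Compound 4, `COc1ccc(-c2cc3cc(-c4ccccc4)cc(C(C)=O)c3[nH]2)cc1`, has not been measured. It differs from compound 3 by methoxy in place of fluoro on an aromatic carbon, the same change that turns compound 1 into compound 2. Since that earlier change gave a number 9.6 percentage points lower from compound 1 to compound 2 (within the scatter), a step within the scatter, the step from compound 3 to compound 4 is expected to be of similar size, a number 9.1 percentage points lower from compound 3 to compound 4 (within the scatter). On that basis compound 4 is estimated to give 76% in this assay, with a likely range from 64% to 88%.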

Compound 4, a percentage reported as activity, at one concentration (the size of the read-out at that concentration, not a potency): 61.5%
The estimate for compound 4 lay 14.5 percentage points above the measured number; the whole stated range lies above it.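

In this assay, replacing 4-fluorophenyl with 4-methoxyphenyl on the core of compound 3 gives a number 23.6 percentage points lower from compound 3 to compound 4 (beyond the scatter), so the number falls on this core as it did on the core of compound 1, where the step stayed within the scatter. Among these compounds, although only one of the two steps passes beyond the scatter, the gap between them does not show that the cores respond differently: the same change on two cores in this assay, a number 9.6 percentage points lower (within the scatter) from compound 1 to compound 2 and a number 23.6 percentage points lower (beyond the scatter) from compound 3 to compound 4, 14 percentage points apart, within the scatter of two such steps. The change therefore carries over in direction across these two cores, but the data do not show that it is larger on one of them, and two cores do not make a rule for the series.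

The compounds shown leave open whether other groups at this place, such as an amine, a carboxylic acid or a longer chain in place of methoxy, would move the number further or reverse it. As far as these compounds go, each value also comes from a single concentration, so it shows only how strong or weak the effect is at that concentration, and whether the compounds would compare in the same way at other concentrations remains open.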